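Dihydroxybenzyl Replacement on a Nucleoside Antiproliferative Series

This account rests on a few compounds, and the source may have more. Where it says the series, first, only, none or still open, it means among the compounds named here.

Compound 1, `OC[C@H]1O[C@@H](n2cnc3c(NCc4ccccc4F)ncnc32)[C@H](O)[C@@H]1O`, in a functional assay on MCF cells (Homo sapiens) for antiproliferative activity, with a stated time of 72 h (on this read-out lower numbers stand for stronger inhibition and higher numbers for weaker inhibition), gives > 166000 nM, which is a limit of the assay and not a number.
Compound 2, `OC[C@H]1O[C@@H](n2cnc3c(NCc4ccc(Br)cc4)ncnc32)[C@H](O)[C@@H]1O`, in this assay gives > 166000 nM, again a limit rather than a number.
Compound 3, `COc1cccc(CNc2ncnc3c2ncn3[C@@H]2O[C@H](CO)[C@@H](O)[C@H]2O)c1O`, in this assay gives 20200 nM.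

Compound 2 therefore stands at the ceiling of what this assay reports, and it shares that ceiling with compound 1, as the limit of > 166000 nM in this assay, at which 2 of the 3 values shown sit, records. Between these two the step is a step that the two limits leave unreadable from compound 1 to compound 2. Only compound 3, carrying a hydroxyl on its phenyl group, returns a real number, and it sits clearly below the ceiling: the step is an at least 8.2-fold lower number from compound 2 to compound 3 (0.91 log units; beyond the scatter), and likewise an at least 8.2-fold lower number from compound 1 to compound 3 (0.91 log units; beyond the scatter).

Compound 4, `OC[C@H]1O[C@@H](n2cnc3c(NCc4cc(O)cc(O)c4)ncnc32)[C@H](O)[C@@H]1O`, has not yet been measured. Against compound 2 the change is 3,5-dihydroxyphenyl in place of 4-bromophenyl on a saturated chain carbon bound to a nitrogen on an aromatic ring. For the measured compounds named here, the one measured step that bears on this is an at least 8.2-fold lower number from compound 2 to compound 3 (0.91 log units; beyond the scatter), where a hydroxyl-bearing phenyl also replaced the 4-bromophenyl and the number fell by at least a modest amount. A fall of similar size, beyond the scatter, is expected here as well, so the estimated step is an at least 5.5-fold lower number from compound 2 to compound 4 (0.74 log units; beyond the scatter). Compound 4 is accordingly expected at about 30000 nM, with a range from 8000 nM to 166000 nM.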

Compound 4, half-maximal inhibitory concentration: > 166000 nM
Compound 4 gave a limit, no number; the forecaster's own chance of this, stated with the estimate: 35%; middle value at least 5.5-fold (0.74 log units) away from the limit.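

In this assay, compound 4 returns a limit of the assay and not a number, so carrying hydroxyl groups on the phenyl ring does not by itself bring a compound off the ceiling, and that ceiling now holds most of the set: the limit of > 166000 nM in this assay, at which 3 of the 4 values shown sit.

For the compounds shown here, the one step that can be read is an at least 8.2-fold higher number from compound 3 to compound 4 (0.91 log units; beyond the scatter), which shows that at this place, on a saturated chain carbon bound to a nitrogen on an aromatic ring, the read-out separates 2-hydroxy-3-methoxyphenyl from 3,5-dihydroxyphenyl even though both carry hydroxyl groups. The steps to compound 4 from compound 1 and from compound 2 join two limits and cannot be read, so the four compounds offer no order among those at the ceiling.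

The compounds shown do not tell whether the readable number of compound 3 depends on its hydroxyl, its methoxy or the two together, and a phenyl ring carrying only one of them would be needed to separate these. Also open, as far as these compounds go, is how a phenyl ring carrying an amine or a carboxylic acid would read in this assay. Compound 3 gives 20200 nM, and whether any group could return a clearly lower number is open as well.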